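Pyridin-4-yl in place of 3-nitrophenyl on the amide carbonyl

The source may hold more compounds than are shown below. What is called first, only, known or untested is meant among the compounds shown, and "the series" means these compounds.

Compound 1 `O=C(Nc1cc(-c2ccccc2)nn1-c1ccccc1)c1cccc([N+](=O)[O-])c1` gives 2220 nM in an assay on HEK293 cells for displacement of a labelled ligand from metabotropic glutamate receptor 5 (Rattus norvegicus) (a higher number here means a weaker inhibitor, a lower number a stronger inhibitor), the second highest of the three numbers at hand. Going by the values given here, compound 2 `O=C(Nc1cc(-c2ccccc2)nn1-c1ccccc1F)c1ccccc1` gives 2700 nM, within the scatter of compound 1, while compound 3 `O=C(Nc1cc(-c2ccccc2)nn1-c1ccccc1Br)c1cccc([N+](=O)[O-])c1` gives 230 nM; the only recorded step, a 9.7-fold lower number from compound 1 to compound 3 (0.98 log units; beyond the scatter), concerns the bromo substituent and not the amide aryl group. Compound 4 `O=C(Nc1cc(-c2ccccc2)nn1-c1ccccc1)c1ccncc1` differs from compound 1 by pyridin-4-yl in place of 3-nitrophenyl on a carbonyl carbon. Among the compounds with values here, no measured step touches this part of the molecule, and compounds 1 and 2 show only that two different amide aryl groups can sit within the scatter of one another. A step of a 1.4-fold higher number from compound 1 to compound 4 (0.13 log units; within the scatter) is therefore expected, close to none beyond the scatter. Compound 4 is estimated at 3000 nM, within 900 nM to 10000 nM.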

Compound 4, inhibition constant: > 10000 nM
Compound 4: only a limit was reported; the forecaster's own chance of this, stated with the estimate: 10%; at least 3.3-fold (0.52 log units) between middle value and limit.
By their numbers in this assay, from the lowest: compound 3; then compounds 1 and 2 (each within the scatter of the next). At a limit, above all of these: compound 4.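

The amide aryl group is not freely exchangeable on this core: pyridin-4-yl in place of 3-nitrophenyl on the carbonyl carbon gives an at least 4.5-fold higher number from compound 1 to compound 4 (0.65 log units; beyond the scatter) in this assay. This is the first step shown at this position, and it lies beyond the scatter. The reading for compound 4 is a limit of the assay and not a number: the limit of > 10000 nM in this assay, at which 1 of the 4 values shown sits.

From the compounds shown here alone, it remains open how far compound 4 lies past its limit. Going by these compounds, it is also open whether an amine or a carboxylic acid in place of the nitro group would keep the number of compound 1.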